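The source may report more compounds than this note shows. Statements on the series, on what has been measured and on what is new or still open speak of the compounds shown alone.

Working notes. Compound 3 `Cc1ccc2c(NCc3ccc(NC(=O)C4CCN(Cc5cccc(F)c5)CC4)cc3)nc(N(C)C)nc2c1` is the reference point. In a functional assay on SV5A8 cells (Homo sapiens) for cytotoxicity (on this read-out higher numbers stand for weaker inhibition and lower numbers for stronger inhibition), compound 3 gives only a limit, > 4170 nM. Compound 1 `Cc1ccc2c(NCc3ccc(NC(=O)C4CCN(Cc5ccc(F)cc5)CC4)cc3)nc(N(C)C)nc2c1` in this assay likewise gives a limit, > 4820 nM. Compound 2 `Cc1ccc(CN2CCC(C(=O)Nc3ccc(CNc4nc(N(C)C)nc5cc(C)ccc45)cc3)CC2)cc1` in this assay also gives a limit, > 4150 nM. All three values thus sit at limits, as shown by the limit of > 4150 nM in this assay, at which 1 of the 3 values shown sits, the limit of > 4170 nM in this assay, at which 1 of the 3 values shown sits, and (the limit of > 4820 nM in this assay, at which 1 of the 3 values shown sits), and the steps a step that the two limits leave unreadable from compound 1 to compound 2, a step that the two limits leave unreadable from compound 1 to compound 3 and a step that the two limits leave unreadable from compound 2 to compound 3 remain unreadable in both size and direction.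

Compound 4 `CCCCN1CCC(C(=O)Nc2ccc(CNc3nc(N(C)C)nc4cc(C)ccc34)cc2)CC1` is not yet measured. It differs from compound 3 by propyl in place of 3-fluorophenyl on a saturated chain carbon bound to an amine nitrogen in a ring. Within the data shown here, none of the measured steps can fix the size of this change: each is bounded at both ends. Among the measured compounds shown here, the only guide is that, among compounds 1, 2 and 3, every variant of the group at this place has stayed at a limit. The expected step that the limit leaves unreadable from compound 3 to compound 4 is accordingly small, within the scatter, with no readable direction. Compound 4 is expected to give about 9000 nM in this assay, in a range from 3500 nM to 30000 nM, and most likely again reported only as a limit.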

Compound 4, half-maximal inhibitory concentration: > 10500 nM
Compound 4 ended at the assay's limit (the forecaster's own chance of this, stated with the estimate: 80%); middle value at least 1.1-fold (0.06 log units) away from the limit.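

In this assay compound 4 also gives only a limit, > 10500 nM. The steps from compound 1, compound 2 and compound 3 to compound 4 therefore cannot be read in size or direction. The compounds shown leave open whether changing this group affects the read-out at all, and at what concentration any of them reaches half-maximal inhibition.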